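The compounds below may be only part of what the source reports. "The series", "measured", "known", "first", "only" and "open" are said of these compounds alone.

Measured so far:
- compound 1 `O=C(Nc1ccc(Oc2ccnc3[nH]ccc23)cc1)c1cc2cccnc2n(-c2ccccc2)c1=O` gives 290 nM
- compound 2 `O=C(Nc1ccc(Oc2ccnc3[nH]ccc23)cc1)c1cc2cccnc2n(-c2ccc(Br)cc2)c1=O` gives 270 nM
- compound 3 `O=C(Nc1ccc(Oc2ccnc3[nH]ccc23)c(F)c1)c1cc2cccnc2n(-c2ccccc2)c1=O` gives 160 nM

All three numbers come from a functional assay on HT-29 cells (Homo sapiens) for antiproliferative activity, read by MTT assay, with a stated time of 72 h; on this read-out higher numbers stand for weaker inhibition and lower numbers for stronger inhibition. Compound 3 holds the lowest of the three numbers, but its neighbours sit close: the gap to compound 2 and the gap to compound 1 are both within the scatter, so no ordering among the three can be claimed.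

Compound 4 `O=C(Nc1ccc(Oc2ccnc3[nH]ccc23)c(F)c1)c1cc2cccnc2n(-c2ccc(Cl)cc2)c1=O` is the next point in the series. It differs from compound 3 by chloro in place of hydrogen on an aromatic carbon. For the measured compounds named here, the one measured step that bears directly on this position is the bromo in place of hydrogen on the same aromatic carbon, a 1.1-fold lower number from compound 1 to compound 2 (0.03 log units; within the scatter), which left the number essentially where it was. The fluoro step a 1.8-fold lower number from compound 1 to compound 3 (0.26 log units; within the scatter) is on the other ring and does not speak to the change here; it is also within the scatter.

Going by the values given here, with only one relevant step, and that one flat, the expectation is a step of no size beyond the scatter, neither up nor down, in this assay. The estimate for compound 4 is therefore 150 nM, with a range of 70 nM to 350 nM, meaning an expected step of a 1.1-fold lower number from compound 3 to compound 4 (0.03 log units; within the scatter).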

Compound 4, half-maximal inhibitory concentration: 82 nM
Compound 4: the middle estimate sits 1.8-fold (0.26 log units) above what was measured; measured number inside the range.
By their numbers in this assay, from the lowest: compounds 4, 3, 2 and 1 (each within the scatter of the next, the first and the last beyond it).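

In this assay, chloro in place of hydrogen on this ring, the change from phenyl to 4-chlorophenyl, gives a 2.0-fold lower number from compound 3 to compound 4 (0.29 log units; within the scatter). This extends the earlier reading in two ways: a second halogen has now been read at this position, and it has been read on the fluoro-bearing compound rather than on compound 1, where the bromo step gave a 1.1-fold lower number from compound 1 to compound 2 (0.03 log units; within the scatter). Both halogen steps stay within the scatter, so the compounds shown give no sign that either halogen moves this read-out, although no measurement at hand bears on what lies behind either step.

Chloro and bromo appear here on different backgrounds, so a direct comparison of the two halogens on one background stays open, as does whether the fluoro group alters the response to a halogen at this position. On these data alone, whether this position responds to groups of another kind also remains open, for example a methoxy group, an amine, a carboxylic acid or a longer chain in place of the halogen.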